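This account rests on a few compounds, and the source may have more. Where it says the series, first, only, none or still open, it means among the compounds named here.

Series notes. Compound 1 `S=c1[nH]nc(Cc2ccc(Cl)cc2Oc2ccccc2Cl)[nH]1` and compound 2 `CCCSc1nnc(Cc2ccc(Cl)cc2Oc2ccccc2Cl)[nH]1` share a core that carries a small substituent on the five-membered aromatic ring. In a functional assay on the whole organism (strain NMRI) with Mus musculus as the target, with a stated time of 60 min, at a dose of 5 mg/kg by the intraperitoneal route (on this read-out lower numbers stand for a weaker effect and higher numbers for a stronger effect at the one dose given), compound 1 gives 124%, and in this assay compound 2 gives 118%; the two values lie within the scatter of each other, so compound 2 is simply the lower of the two numbers, not a weaker compound. Compound 3 `CCOc1nnc(Cc2ccc(Cl)cc2Oc2ccccc2Cl)[nH]1` is not yet measured. It differs from compound 2 in one place (ethoxy in place of propylsulfanyl on an aromatic carbon). For the measured compounds named here, with only two close numbers as a guide, no step beyond the scatter is expected, and the estimated step of a number 6 percentage points lower from compound 2 to compound 3 (within the scatter) is small. For compound 3 the expected value in this assay is 112%, with a range from 88% to 136%.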

Compound 3, a percentage reported as activity, at one dose (the size of the read-out at that dose, not a potency): 120%
The estimate for compound 3 lay 8 percentage points below the measured number; low and high end bracket the measured number.
By their numbers in this assay, from the lowest: compounds 2, 3 and 1 (each within the scatter of the next).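

In this assay the swap of propylsulfanyl for ethoxy on this aromatic carbon gives a number 2 percentage points higher from compound 2 to compound 3 (within the scatter) and so shows no step beyond the scatter, whether sulfur or oxygen bears the chain. The wider change gives a number 4 percentage points lower from compound 1 to compound 3 (within the scatter) and likewise leaves compound 3 within the scatter of compound 1. Nothing available bears on a cause for these results.

As far as these compounds go, whether an amine, a carboxylic acid or a longer chain on this carbon would separate from these numbers remains open. The single dose also leaves relative potency open.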